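Sulfonamide series: acyl variation on the proline nitrogen

The source may hold more compounds than are shown below. What is called first, only, known or untested is meant among the compounds shown, and "the series" means these compounds.

Measured so far:
compound 1, `CC(C)(C)CC(=O)N1CCC[C@H]1C(=O)N1CCC(NS(=O)(=O)c2cc(S(=O)(=O)c3ccccc3)ccc2C(F)(F)F)CC1`, 20 nM in an assay on isolated protein for binding affinity to secreted frizzled-related protein 1 (Homo sapiens), read by fluorescence; a higher number here means a weaker inhibitor, a lower number a stronger inhibitor
compound 2, `CN(C)c1ccc(C(=O)N2CCC[C@H]2C(=O)N2CCC(NS(=O)(=O)c3cc(S(=O)(=O)c4ccccc4)ccc3C(F)(F)F)CC2)cc1`, 110 nM in this assay

Compound 2 gives the higher of the two numbers recorded so far in this assay; its nearest neighbour is compound 1, and the step from compound 1 is a 5.5-fold higher number from compound 1 to compound 2 (0.74 log units; beyond the scatter), which is beyond the scatter. That step is the only one available, and it exchanges the neopentyl group on the carbonyl carbon for 4-(dimethylamino)phenyl.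

Compound 3, `O=C([C@@H]1CCCN1C(=O)N1CCOCC1)N1CCC(NS(=O)(=O)c2cc(S(=O)(=O)c3ccccc3)ccc2C(F)(F)F)CC1`, is not yet measured. It differs from compound 2 as follows: morpholin-4-yl in place of 4-(dimethylamino)phenyl on a carbonyl carbon. For the measured compounds named here, the step from compound 1 to compound 2 shows that this carbonyl position tolerates a change of group with a modest loss; it does not show how a morpholin-4-yl group compares with 4-(dimethylamino)phenyl, since no measured pair covers that exchange. Going by the values given here, with no direct precedent, the expectation is a step no larger than the scatter, as a 1.2-fold higher number from compound 2 to compound 3 (0.07 log units; within the scatter). Compound 3 is therefore estimated at 130 nM, with a likely range from 40 nM to 450 nM.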

Compound 3, half-maximal inhibitory concentration: 40 nM
For compound 3 the middle estimate is 3.3-fold (0.51 log units) above the measured one, within the range that was stated.
By their numbers in this assay, from the lowest: compounds 1 and 3 (each within the scatter of the next); then compound 2.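

In this assay, morpholin-4-yl in place of 4-(dimethylamino)phenyl on the carbonyl carbon gives a 2.8-fold lower number from compound 2 to compound 3 (0.44 log units; beyond the scatter), so the loss seen on leaving neopentyl does not follow every exchange at this position. With a 2.0-fold higher number from compound 1 to compound 3 (0.30 log units; within the scatter), morpholin-4-yl and neopentyl cannot be told apart here, and among the three compounds shown, only the 4-(dimethylamino)phenyl group of compound 2 stands apart from the other two, a non-aromatic ring and an open branched chain being equally accommodated on this carbonyl carbon. Nothing available explains why these groups differ.

On these data alone, it remains open whether the higher number of compound 2 goes with the aromatic ring itself or with its dimethylamino group, and a plain phenyl group on the same carbonyl carbon would separate the two. As far as these compounds go, it is equally open whether the oxygen of morpholin-4-yl contributes anything, a question that piperidin-1-yl, with a carbon in its place, would address, while a free amine such as piperazin-1-yl would extend the comparison to a ring carrying a hydrogen-bond donor.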